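Side-chain change on compound 2 of the series

The compounds below may be only part of what the source reports. "The series", "measured", "known", "first", "only" and "open" are said of these compounds alone.

Measured in an ADME assay on blood (Rattus norvegicus) for metabolic stability, with a stated time of 2 h; a higher number here means that more of the compound is left, a lower number that less of the compound is left:
- compound 1 `CCC(=O)c1ccc(N(C)C(=O)CSc2nnc(CNc3ccccc3)n2CC)cc1` gives 1.9%
- compound 2 `CCn1c(CNc2ccccc2)nnc1SCc1nc2cc(C(=O)C(C)C)ccc2o1` gives 42%

Compound 2 stands highest of the two numbers, at 42%, and compound 1 lies lower, at 1.9%, a gap beyond the usual scatter. For the measured compounds named here, the measured pair does not offer a step at a single place, so the series has no direct precedent for the next change.

Compound 3 `CCC(O)c1ccc2oc(CSc3nnc(CNc4ccccc4)n3CC)nc2c1` is not yet measured. It differs from compound 2 at one place: 1-hydroxypropyl in place of isopropylcarbonyl on an aromatic carbon. In words, 1-hydroxypropyl stands in place of isopropylcarbonyl on an aromatic carbon.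

Going by the values given here, with no measured step to draw on, the expectation rests on the structural change alone and is loosely founded. No step beyond the scatter is expected in this assay, with only a slight lean upward. The estimated change is a number 5 percentage points higher from compound 2 to compound 3 (within the scatter). In this assay the expected value for compound 3 is 47%, with an estimated range of 20% to 75%.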

Compound 3, percent of the compound remaining: 80%
For compound 3 the middle estimate is 33 percentage points below the measured one; the measured number lies above the stated range.
By their numbers in this assay, from the lowest: compound 1; then compound 2; then compound 3.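

In this assay, for the compounds shown here, placing 1-hydroxypropyl instead of isopropylcarbonyl on this aromatic carbon gives a number 38 percentage points higher from compound 2 to compound 3 (beyond the scatter), and this is the first step that can be read at a single place, showing that the read-out responds strongly to the group held there. The exchange alters several counted features at once: the double bond outside the aromatic rings leaves, 1 hydrogen-bond donor enters, and 4 heavy atoms stand in place of 5, so the step belongs to the whole exchange and not to any one of these features. Nothing available bears on the origin of the step.

The compounds shown leave open how much of the step follows the hydroxyl and how much follows the change in the carbon chain, a question that a propanoyl or 1-methoxypropyl group on the same aromatic carbon would help to separate. They also leave open whether a longer hydroxyalkyl chain, an amine or a carboxylic acid at this place would hold the value of compound 3 at 80% in this assay.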